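This account rests on a few compounds, and the source may have more. Where it says the series, first, only, none or still open, it means among the compounds named here.

Of the compounds shown here, three of one family have been measured in a functional assay (Cavia porcellus) for antagonist activity at Serotonin 3 (5-HT3) receptor (Homo sapiens); on this read-out lower numbers stand for stronger inhibition and higher numbers for weaker inhibition. Compound 1, `O=C1N(c2ccccc2)CCN1C1CN2CCC1CC2`, gives 2100 nM. Compound 2, `O=C1N(c2cccc(Br)c2)CCN1C1CN2CCC1CC2`, gives 38.3 nM. Compound 3, `Cc1[nH]cnc1CN1CCN(c2ccccc2)C1=O`, gives 26.9 nM. Going by the values given here, the only single-site step among them is a 55-fold lower number from compound 1 to compound 2 (1.74 log units; beyond the scatter); putting a bromo in place of a hydrogen on the aromatic ring thus brought a large drop in the number. Compound 3 gives the lowest of the three numbers, yet its value and that of compound 2 lie within the scatter of each other, so nothing separates the two; only compound 1 stands clearly apart, with a far higher number.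

Compound 4, `Cc1cccc(N2CCN(Cc3nc[nH]c3C)C2=O)c1`, differs from compound 3 in one place: methyl in place of hydrogen on an aromatic carbon, the new group sitting on an aromatic carbon of a six-membered aromatic ring of carbon only, meta to a large group. Among the compounds with values here, the step from compound 1 to compound 2 is the only measured guide, and it concerns the same aromatic ring but a bromo rather than a methyl, so its size cannot simply be carried over. A lowering of the number is nevertheless expected, smaller than that step, in this assay. Compound 4 is therefore estimated at 10 nM, with a range from 3 nM to 40 nM, a change of a 2.7-fold lower number from compound 3 to compound 4 (0.43 log units; beyond the scatter).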

Compound 4, antagonist equilibrium constant: 45.7 nM
Estimate against measurement, compound 4: 4.6-fold (0.66 log units) below, outside the stated range (above it).
By their numbers in this assay, from the lowest: compounds 3, 2 and 4 (each within the scatter of the next); then compound 1.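

In this assay, a methyl on an aromatic carbon of the six-membered ring, meta to a large group, gives a 1.7-fold higher number from compound 3 to compound 4 (0.23 log units; within the scatter), so compound 3 and compound 4 cannot be told apart, and on the core of compound 3 this position accepts the added methyl without a measurable change in the number. Going by these compounds alone, the only earlier guide on this ring was the bromo step, a 55-fold lower number from compound 1 to compound 2 (1.74 log units; beyond the scatter), and the new result shows that such a large step does not appear with every small group added to the ring, although that comparison changes both the group and the core. Nothing available here explains why the two steps differ in size.

From the compounds shown here alone, it remains open whether the large bromo step belongs to the bromo itself or to the core of compound 1, a question that a methyl on compound 1 or a bromo on compound 3 could settle. Going by these compounds, it also remains open how a chloro, a methoxy or a trifluoromethyl in this same place on compound 3 would read in this assay.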